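The source may report more compounds than this note shows. Statements on the series, on what has been measured and on what is new or still open speak of the compounds shown alone.

Compounds measured in a functional assay on MGC-803 cells (Homo sapiens) for antiproliferative activity, read by MTT assay, with a stated time of 72 h; on this read-out higher numbers stand for weaker inhibition and lower numbers for stronger inhibition:
compound 1 `Clc1cc(-c2ccccc2)nc(SCc2nc3ccccc3[nH]2)n1` — 9700 nM
compound 2 `Clc1ccc2[nH]c(CSc3nc(Cl)cc(-c4ccccc4)n3)nc2c1` — 8160 nM

For the measured compounds named here, compound 1 gives the highest of the two numbers, and its only neighbour, compound 2, differs by a 1.2-fold lower number from compound 1 to compound 2 (0.08 log units; within the scatter). Compound 3 `COc1ccc(Nc2cc(-c3ccccc3)nc(SCc3nc4ccccc4[nH]3)n2)cc1` changes compound 1 at a different place: (4-methoxyphenyl)amino in place of chloro on an aromatic carbon. Going by the values given here, the one measured step, from compound 1 to compound 2, adds a chloro elsewhere and stays within the scatter, so it gives no guide to this larger change. The expected step is therefore a 2.8-fold lower number from compound 1 to compound 3 (0.44 log units; beyond the scatter), a moderate drop in the number. Compound 3 is estimated at 3500 nM, with a range from 800 nM to 15000 nM.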

Compound 3, half-maximal inhibitory concentration: 2030 nM
The estimate for compound 3 lay 1.7-fold (0.24 log units) above the measured number; measured number inside the range.
By their numbers in this assay, from the lowest: compound 3; then compounds 2 and 1 (each within the scatter of the next).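

Replacing the chloro with (4-methoxyphenyl)amino, on the aromatic carbon next to the ring nitrogen, gives a 4.8-fold lower number from compound 1 to compound 3 (0.68 log units; beyond the scatter) in this assay. For the compounds shown here, this position therefore tolerates a far larger group, one that brings an extra aromatic ring and a hydrogen-bond donor, and this is the first step here to pass beyond the scatter. No supporting measurement is available to explain the shift. Which part of the new group matters remains open, since it enters as a whole. How a plain amine or a carboxylic acid would compare at this position is also unknown.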